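Two anilinopyrimidines and a benzylamine in a liver-cell growth assay

This account rests on a few compounds, and the source may have more. Where it says the series, first, only, none or still open, it means among the compounds named here.

Compound 1: `Cc1ccc(Nc2ncc(Cl)c(Nc3ccccc3C)n2)cc1` gives > 100000 nM
Compound 2: `Cc1ccccc1Nc1nc(Nc2ccc(N3CCN(C(=O)OC(C)(C)C)CC3)cc2)ncc1Cl` gives 1750 nM
Compound 3: `CN1CCN(c2ccc(Nc3ncc(Cl)c(NCc4ccc(F)cc4)n3)nc2)CC1` gives 39700 nM

Three compounds sharing a chlorinated pyrimidine core were tested in an ADME assay on L02 cells (Homo sapiens) for inhibition, read by CCK-8 assay, with a stated time of 48 h; a lower number here means a stronger inhibitor of growth, a higher number a weaker inhibitor of growth. For compound 1 the result is a limit of the assay, not a number: the limit of > 100000 nM in this assay, at which 1 of the 3 values shown sits. Of the two compounds with numbers, compound 3 stands highest, and compound 2 sits well below it, a gap beyond the usual scatter.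

Compound 4, `COc1ccc(Nc2nc(Nc3ccc(N4CCN(C)CC4)cn3)ncc2Cl)cc1`, has not yet been measured in this assay. It differs from compound 3 in one place: 4-methoxyphenyl in place of 4-fluorobenzyl on a nitrogen on an aromatic ring. Going by the values given here, no step between measured compounds matches this change, so its size is not known from the data. Compound 2, which also carries an aryl rather than a benzyl group on that nitrogen, gives the lower number, and on that pattern compound 4 is expected to give a lower number than compound 3, a step of a 4.0-fold lower number from compound 3 to compound 4 (0.60 log units; beyond the scatter). The estimate for compound 4 in this assay is 10000 nM, within 2500 nM to 40000 nM.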

Compound 4, concentration for 50% growth inhibition: 3150 nM
The estimate for compound 4 lay 3.2-fold (0.50 log units) above the measured number; low and high end bracket the measured number.
By their numbers in this assay, from the lowest: compounds 2 and 4 (each within the scatter of the next); then compound 3. At a limit, above all of these: compound 1.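

Exchanging 4-fluorobenzyl for 4-methoxyphenyl on a nitrogen on an aromatic ring gives, in this assay, a 13-fold lower number from compound 3 to compound 4 (1.10 log units; beyond the scatter), the only step shown between measured compounds that differ in one place. It shows that this position matters for the growth reading: with the rest of compound 3 unchanged, this one exchange moves the number beyond the scatter. Nothing measured here explains the size of this step.

The step combines two changes, so 4-fluorophenyl or 4-methoxybenzyl on this nitrogen would be needed to separate the carbon linking ring to nitrogen from the exchange of fluorine for methoxy. As far as these compounds go, whether the step extends to other groups at this place, such as a plain alkyl chain or a cyclohexyl ring, also remains open.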